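A Second 3-Methylbut-2-en-1-yl Group on Compound 2

The source may report more compounds than this note shows. Statements on the series, on what has been measured and on what is new or still open speak of the compounds shown alone.

Of the compounds shown here, three have been tested in a functional assay on HT-29 cells (Homo sapiens) for cytotoxicity, read by XTT assay, with a stated time of 72 h; a higher number here means a weaker inhibitor, a lower number a stronger inhibitor. Compound 1 `CCCCCCCC/C=C\CCCCCCCCc1c(O)cc(O)c(C(C)=O)c1O` reaches only a limit of the assay, > 100000 nM. Compound 2 `CC(=O)c1c(O)cc(O)c(CC=C(C)C)c1O` gives 28000 nM, and compound 3 `CC(C)=CCC/C=C(\C)Cc1c(O)cc(O)c2c(=O)c(O)c(-c3ccc(O)cc3)oc12` gives 30000 nM. For the measured compounds named here, these two numbers lie within the scatter of each other, so compound 2 stands level with compound 3, and they are the only two values that are true numbers.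

Compound 4 `CC(=O)c1c(O)c(CC=C(C)C)c(O)c(CC=C(C)C)c1O` has not yet been measured. It differs from compound 2 by 3-methylbut-2-en-1-yl in place of hydrogen on an aromatic carbon: a 3-methylbut-2-en-1-yl group takes the place of hydrogen on an aromatic carbon. That carbon is meta to the 3-methylbut-2-en-1-yl group of compound 2, meta to an acetyl group and para to a hydroxy group.

Going by the values given here, no measured pair isolates this change, so only a modest step towards a lower number is expected in this assay, one that may barely clear the scatter. The expected change is a 2.3-fold lower number from compound 2 to compound 4 (0.37 log units; beyond the scatter). Compound 4 is estimated at 12000 nM, with an expected range of 3500 nM to 35000 nM.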

Compound 4, half-maximal inhibitory concentration: > 100000 nM
Compound 4 ended at the assay's limit (the forecaster's own chance of this, stated with the estimate: 5%); at least 8.3-fold (0.92 log units) between middle value and limit.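

For the compounds shown here, until compound 4, no pair of compounds isolated a change on this aromatic carbon, which lies ortho to two hydroxy groups and para to a hydroxy group, so this is the first reading of the position. In this assay, as far as these compounds go, 3-methylbut-2-en-1-yl in place of hydrogen there gives an at least 3.5-fold higher number from compound 2 to compound 4 (0.55 log units; beyond the scatter), so the second group weakens compound 2 rather than strengthening it, and the true size of the step stays unknown. Compound 4 sits at a limit of the assay, not at a number: the limit of > 100000 nM in this assay, at which 2 of the 4 values shown sit.

The compounds shown leave open whether a smaller group on this carbon, such as a methyl group, would also cost activity. They also leave open how an amine or a carboxylic acid in the same place would read.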